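Adding a Second Methyl to a Methylphenyl Ketone

The compounds below may be only part of what the source reports. "The series", "measured", "known", "first", "only" and "open" are said of these compounds alone.

Three compounds have so far been measured in an ADME assay on C8166 cells (Homo sapiens) for cytotoxicity, read by colorimetric assay and MTT assay; on this read-out higher numbers stand for lower toxicity in this test and lower numbers for higher toxicity in this test:
Compound 1, `Cc1cccc(C(=O)c2c(OCC(=O)Nc3ccc(S(N)(=O)=O)cc3C)ccc3ccccc23)c1`, gives 40400 nM.
Compound 2, `Cc1cc(C)cc(C(=O)c2c(OCC(=O)Nc3ccc(S(N)(=O)=O)cc3C)ccc3ccccc23)c1`, gives 39100 nM.
Compound 3, `Cc1ccc(C(=O)c2c(OCC(=O)Nc3ccc(S(N)(=O)=O)cc3C)ccc3ccccc23)c(C)c1`, gives 25500 nM.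

Compound 1 carries the highest number of the three, yet a 1.0-fold lower number from compound 1 to compound 2 (0.01 log units; within the scatter) and a 1.6-fold lower number from compound 1 to compound 3 (0.20 log units; within the scatter) both stay within the scatter, so none of the three is separated from the others in this assay.

Compound 4, `Cc1ccc(C(=O)c2c(OCC(=O)Nc3ccc(S(N)(=O)=O)cc3C)ccc3ccccc23)cc1C`, differs from compound 1 by methyl in place of hydrogen on an aromatic carbon. Among the compounds with values here, the closest precedent is a 1.0-fold lower number from compound 1 to compound 2 (0.01 log units; within the scatter), likewise a methyl in place of hydrogen on an aromatic carbon, and a 1.5-fold lower number from compound 2 to compound 3 (0.19 log units; within the scatter), which rearranges the methyls, is also within the scatter. A step no larger than the scatter is therefore expected for compound 4 in this assay: a 1.1-fold lower number from compound 1 to compound 4 (0.04 log units; within the scatter). Compound 4 is estimated at 37000 nM, with a range from 20000 nM to 70000 nM.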

Compound 4, half-maximal cytotoxic concentration: 33000 nM
For compound 4 the middle estimate is 1.1-fold (0.05 log units) above the measured one, within the range that was stated.
By their numbers in this assay, from the lowest: compounds 3, 4, 2 and 1 (each within the scatter of the next).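

A methyl group on this carbon, ortho to a methyl group and para to a large group, leaves the number within the scatter in this assay, with a 1.2-fold lower number from compound 1 to compound 4 (0.09 log units; within the scatter) as the step. The 3,4-dimethylphenyl group also stays within the scatter of the other two dimethylphenyl groups, with a 1.3-fold higher number from compound 3 to compound 4 (0.11 log units; within the scatter) and a 1.2-fold lower number from compound 2 to compound 4 (0.07 log units; within the scatter) as the steps, so these compounds do not separate the three methyl arrangements. Nothing available here explains this flat result.

As far as these compounds go, whether a different group on this carbon, such as an amine, a carboxylic acid or a longer chain, would move the number beyond the scatter remains open.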